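Swapping the fluorinated aryl for a phenol on compound 1

A few compounds are considered here, and "the series" means these few. Any claim that something is new, unique, unknown or untested is made for them only; others in the source may bear on it.

Measured so far:
- compound 1 `O=C1O/C(=C\Cn2cc(-c3cc(F)cc(F)c3)nn2)C(OCc2ccccc2)=C1OCc1ccccc1`: in a functional assay on SW-620 cells (Homo sapiens) for antiproliferative activity, read by MTT assay, with a stated time of 72 h (on this read-out higher numbers stand for weaker inhibition and lower numbers for stronger inhibition), compound 1 gives > 100000 nM, which is a limit of the assay rather than a number.
- compound 2 `O=C1O[C@H]([C@@H](O)Cn2cc(CNS(=O)(=O)c3ccc(F)cc3)nn2)C(OCc2ccccc2)=C1OCc1ccccc1`: compound 2 gives 41100 nM.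
- compound 3 `COc1ccccc1-c1cn(C[C@H](O)[C@H]2OC(=O)C(OCc3ccccc3)=C2OCc2ccccc2)nn1`: compound 3 gives > 100000 nM, also a limit of the assay.

Compound 1 therefore sits at the top edge of what this assay can report, alongside compound 3, because of the limit of > 100000 nM in this assay, at which 2 of the 3 values shown sit. Only compound 2 gives a real number. Among the compounds with values here, the one measured step, an at least 2.4-fold higher number from compound 2 to compound 3 (0.38 log units; beyond the scatter), belongs to a different pair and does not touch the change studied here.

Compound 4 `O=C1O/C(=C\Cn2cc(-c3cccc(O)c3)nn2)C(OCc2ccccc2)=C1OCc1ccccc1` differs from compound 1 by 3-hydroxyphenyl in place of 3,5-difluorophenyl on an aromatic carbon. Within the data shown here, no measured step bears on this exchange, so there is no basis for expecting a move beyond the scatter in either direction in this assay. The estimate for compound 4 is therefore anchored on compound 1 and is expected to stay near the limit: 100000 nM, between 30000 nM and 300000 nM, meaning an expected step of a number no higher from compound 1 to compound 4 (the limit leaves the size open).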

Compound 4, half-maximal inhibitory concentration: 69800 nM
Beside the measured number, compound 4's estimate is 1.4-fold (0.16 log units) above it, within the range that was stated.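

Compound 4 shows that the core of compound 1 can give a real number in this assay when 3-hydroxyphenyl sits on this aromatic carbon, which compound 1, carrying 3,5-difluorophenyl, did not. The exchange reads as an at least 1.4-fold lower number from compound 1 to compound 4 (0.15 log units; that floor lies within the scatter), so the numbers shown do not establish a real gain in activity from this change. Its true size stays open because compound 1 gives only a limit of the assay, not a number: the limit of > 100000 nM in this assay, at which 2 of the 4 values shown sit.

The compounds shown do not separate the part played by the added hydroxyl from the part played by the two departing fluorines. Also open, going by these compounds, is what an unsubstituted phenyl or a 3-aminophenyl group would give on this same aromatic carbon, with the rest of compound 4 kept unchanged.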